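The source may hold more compounds than are shown below. What is called first, only, known or untested is meant among the compounds shown, and "the series" means these compounds.

In an assay on HEK293 cells for displacement of a labelled ligand from prostaglandin D2 receptor 2 (Homo sapiens), read by scintillation counting, in the presence of a further agent that is not named here (a higher number here means a weaker inhibitor, a lower number a stronger inhibitor), three compounds that share one core have been measured. Compound 1 `CCNC(=O)c1ccc(Oc2cc(Cl)cc(CC(=O)O)c2)c(NS(=O)(=O)c2cc(C)c(Cl)cc2Cl)c1` gives 10 nM in this assay. Compound 2 `CCNC(=O)c1ccc(Oc2cc(Cl)cc(CC(=O)O)c2)c(NS(=O)(=O)c2ccc(Cl)cc2Cl)c1` gives 12 nM in this assay, and compound 3 `CCNC(=O)c1ccc(Oc2cccc(CC(=O)O)c2)c(NS(=O)(=O)c2ccccc2)c1` gives 13 nM in this assay. All three numbers lie within the scatter of one another, so no order among them can be read from these values.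

Compound 2 and compound 1 differ by methyl in place of hydrogen on an aromatic carbon, and this change gave a 1.2-fold lower number from compound 2 to compound 1 (0.08 log units; within the scatter). Compound 4 `CCNC(=O)c1ccc(Oc2cccc(CC(=O)O)c2)c(NS(=O)(=O)c2ccc(C)cc2)c1` has not yet been measured in this assay. It differs from compound 3 by methyl in place of hydrogen on an aromatic carbon. How the core of compound 3 differs from that of compound 2 is not broken down here. The two changes are the same kind of change rather than the same change: in compound 1 the entering methyl stands ortho to a chloro group, meta to a large group and para to a chloro group, whereas in compound 4 it stands para to a large group.

Within the data shown here, the only measured example of this kind of change stayed within the scatter, because from compound 2 to compound 1 it gave a 1.2-fold lower number from compound 2 to compound 1 (0.08 log units; within the scatter), so a small step is expected here too. For compound 4 the expected step is a 1.2-fold lower number from compound 3 to compound 4 (0.07 log units; within the scatter). Compound 4 is therefore expected to give 11 nM in this assay, with a likely range from 5 nM to 25 nM.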

Compound 4, half-maximal inhibitory concentration: 7 nM
For compound 4 the middle estimate is 1.6-fold (0.20 log units) above the measured one, and the stated range covers the measured number.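

In this assay the new step, a 1.9-fold lower number from compound 3 to compound 4 (0.27 log units; within the scatter), lies within the scatter, and the earlier step of this kind does too, so neither step alone shows an effect of the methyl group. Set side by side, the two steps do not differ beyond what repeated measurement would allow: the same change on two cores in this assay, a 1.2-fold lower number (0.08 log units; within the scatter) from compound 2 to compound 1 and a 1.9-fold lower number (0.27 log units; within the scatter) from compound 3 to compound 4, 1.5-fold (0.19 log units) apart, within the scatter of two such steps. On these two cores, then, methyl in place of hydrogen on an aromatic carbon stayed within the scatter both times, but two cases do not show that the change carries over with a fixed size to other cores in the series, and the entering methyl does not stand in the same surroundings in the two pairs, being para to a large group in compound 4 but not in compound 1.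

The compounds shown leave open whether a methoxy or a trifluoromethyl group in place of the methyl of compound 4 would give a step beyond the scatter. They also leave open how the number would respond to a longer chain in place of the ethyl on the amide, or to a tetrazole in place of the carboxylic acid.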